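Trifluoromethyl for fluoro on two related cores

This account rests on a few compounds, and the source may have more. Where it says the series, first, only, none or still open, it means among the compounds named here.

Compound 1 `O=C1/C(=C/c2cccc(F)c2)CCc2cc(O)ccc21` and compound 2 `O=C1/C(=C/c2cccc(C(F)(F)F)c2)CCc2cc(O)ccc21` share one core; compound 3 `O=C1/C(=C/c2ccc(F)cc2)CCc2ccc(O)cc21` and compound 4 `O=C1/C(=C/c2ccc(C(F)(F)F)cc2)CCc2ccc(O)cc21` share another, and the difference between the two cores is not broken down here. In a functional assay on RAW264.7 cells (Mus musculus) for inhibition (on this read-out higher numbers stand for weaker inhibition and lower numbers for stronger inhibition), compound 1 gives 1230 nM, compound 2 gives 180 nM, and compound 3 gives 840 nM. The change trifluoromethyl in place of fluoro on an aromatic carbon produced a 6.8-fold lower number from compound 1 to compound 2 (0.83 log units; beyond the scatter). The change trifluoromethyl in place of fluoro on an aromatic carbon is the same kind of change, but its place is para to a large group where the earlier one was meta to a large group. Because the only shown instance of this change is a 6.8-fold lower number from compound 1 to compound 2 (0.83 log units; beyond the scatter), compound 4 is expected to make a step of similar size, a 4.2-fold lower number from compound 3 to compound 4 (0.62 log units; beyond the scatter), with some allowance for the different place. The estimate for compound 4 in this assay is 200 nM, between 80 nM and 500 nM.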

Compound 4, half-maximal inhibitory concentration: > 10000 nM
Compound 4 was reported as a limit (the forecaster's own chance of this, stated with the estimate: 3%); middle value at least 50-fold (1.69 log units) from the limit.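

Trifluoromethyl in place of fluoro gave an at least 11-fold higher number from compound 3 to compound 4 (1.07 log units; beyond the scatter) in this assay, so the improvement seen on the core of compound 1 did not carry over to the core of compound 3: the same change on two cores in this assay, a 6.8-fold lower number (0.83 log units; beyond the scatter) from compound 1 to compound 2 and an at least 11-fold higher number (1.07 log units; beyond the scatter) from compound 3 to compound 4, at least 81-fold (1.91 log units) apart, beyond the scatter of two such steps Compound 4 gives > 10000 nM, which is a limit of the assay and not a number: the limit of > 10000 nM in this assay, at which 1 of the 4 values shown sits. The two pairs show that this change cannot be assumed to act alike across these cores, but they do not show whether the core or the place of the group accounts for the difference.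

From the compounds shown here alone, it remains open how a chloro, a methoxy or a nitrile group would behave in the same place on either core.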